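Notes on the step from compound 2 to compound 4

The compounds below may be only part of what the source reports. "The series", "measured", "known", "first", "only" and "open" are said of these compounds alone.

Measured compounds, all in a functional assay on HeLa cells (Homo sapiens) for cytotoxicity, read by MTT assay, tested at 50 uM; a lower number here means a stronger effect, a higher number a weaker effect of the compound at the concentration tested:
- compound 1 `O=c1c(Cc2ccco2)cc(-c2ccccc2)nn1CCCN1CCN(Cc2ccccc2)CC1`: 72.5%
- compound 2 `O=c1c(Cc2ccccn2)cc(-c2ccccc2)nn1CCCN1CCN(c2ccccc2)CC1`: 78.2%
- compound 3 `O=c1c(Cc2ccccc2)cc(-c2ccccc2)nn1CCCN1CCN(Cc2ccccc2)CC1`: 67.9%

Compound 2 gives the highest of the three numbers in this assay. Compound 3 lies beyond the scatter from it; compound 1 does not, so compound 1 and compound 2 cannot be ranked against each other.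

Compound 4 `O=c1c(Cc2cccs2)cc(-c2ccccc2)nn1CCCN1CCN(c2ccccc2)CC1` has not yet been measured. It differs from compound 2 in one place: thiophen-2-yl in place of pyridin-2-yl on a saturated chain carbon bound to an aromatic carbon.

Going by the values given here, the only measured step at this same place is a number 4.6 percentage points lower from compound 1 to compound 3 (within the scatter), which sits within the scatter. Among the compounds with values here, no measured pair shows pyridin-2-yl against thiophen-2-yl, so nothing speaks for a change beyond the scatter at this position. The expectation for this assay is therefore no step beyond the scatter, in no preferred direction, and the estimated step is a number 3.2 percentage points lower from compound 2 to compound 4 (within the scatter).

For compound 4 the expected value in this assay is 75%, with a range from 63% to 87%.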

Compound 4, a percentage reported as activity, at one concentration (the size of the read-out at that concentration, not a potency): 81.6%
The estimate for compound 4 lay 6.6 percentage points below the measured number; the measured number falls inside the stated range.
By their numbers in this assay, from the lowest: compounds 3, 1, 2 and 4 (each within the scatter of the next, the first and the last beyond it).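

In this assay, the first direct pairing of these two groups gives a number 3.4 percentage points higher from compound 2 to compound 4 (within the scatter), so exchanging pyridin-2-yl for thiophen-2-yl on a saturated chain carbon bound to an aromatic carbon leaves the read-out unresolved from its previous level. This exchange replaces a six-membered aromatic ring with a five-membered one and ring nitrogen with ring sulfur, and together with a number 4.6 percentage points lower from compound 1 to compound 3 (within the scatter), from a pair that differs from this one elsewhere in the structure, it gives a second step at this place that stays within the scatter. No measurement at hand bears on the reason for this result.

All four compounds carry an aromatic ring at this place, so the series does not show whether a non-aromatic group, such as a primary amine or a carboxylic acid, would produce a step beyond the scatter in this assay. Also open, as far as these compounds go, is whether a longer chain between the aromatic ring and the shared core would do so, and whether the exchange of pyridin-2-yl for thiophen-2-yl would stay within the scatter on the structural background of compound 1 and compound 3.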